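Ortho-methyl anilino analogue of compound 1 in the series

The source may report more compounds than this note shows. Statements on the series, on what has been measured and on what is new or still open speak of the compounds shown alone.

Among the measured compounds shown here, compound 1 `Fc1cccc(-c2nc(Nc3ccccc3)c3cc(F)ccc3n2)c1` is, among the numbers so far, the highest of the two values given in a functional assay on HL-60 cells (Homo sapiens) for cytotoxicity, read by MTT assay, with a stated time of 48 h; a higher number here means a weaker inhibitor, a lower number a stronger inhibitor; in this assay compound 1 gives 48300 nM. Compound 2 `Fc1cccc(-c2nc(Nc3ccc(Cl)cc3)c3cc(F)ccc3n2)c1` gives 45700 nM in this assay, and the step of a 1.1-fold lower number from compound 1 to compound 2 (0.02 log units; within the scatter) is within the scatter. Compound 3 `Cc1cccc(Nc2nc(-c3cccc(F)c3)nc3ccc(F)cc23)c1` returns only a limit in this assay, > 50000 nM, not a number; this is the limit described as the limit of > 50000 nM in this assay, at which 1 of the 3 values shown sits. The steps of an at least 1.0-fold higher number from compound 1 to compound 3 (0.01 log units; that floor lies within the scatter) and an at least 1.0-fold higher number from compound 2 to compound 3 (0.03 log units; that floor lies within the scatter) therefore have floors that lie within the scatter.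

Compound 4 `Cc1ccccc1Nc1nc(-c2cccc(F)c2)nc2ccc(F)cc12` is not yet measured. Against compound 1 it differs by methyl in place of hydrogen on an aromatic carbon. For the measured compounds named here, the only measured step of the same kind, a methyl in place of hydrogen on an aromatic carbon, is an at least 1.0-fold higher number from compound 1 to compound 3 (0.01 log units; that floor lies within the scatter), and the chloro step a 1.1-fold lower number from compound 1 to compound 2 (0.02 log units; within the scatter) likewise stayed within the scatter. No step beyond the scatter is therefore expected in this assay, in either direction. Compound 4 is expected to give about 50000 nM, with a plausible range of 25000 nM to 100000 nM, which would mean a step of a 1.0-fold higher number from compound 1 to compound 4 (0.02 log units; within the scatter); since compound 1 already sits close to the limit, a limit rather than a number is a real possibility.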

Compound 4, half-maximal inhibitory concentration: > 50000 nM
Compound 4 was reported as a limit (the forecaster's own chance of this, stated with the estimate: 50%); the middle value sits exactly at the limit.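

In this assay, the change from anilino to (2-methylphenyl)amino reads as an at least 1.0-fold higher number from compound 1 to compound 4 (0.01 log units; that floor lies within the scatter), and the exchange of 4-chlorophenyl for 2-methylphenyl reads as an at least 1.0-fold higher number from compound 2 to compound 4 (0.03 log units; that floor lies within the scatter); neither floor lies beyond the scatter, so neither step establishes a loss. Compound 3 and compound 4 both stand at a limit, so the step between them cannot be read and the two methyl placements cannot be ranked: the limit of > 50000 nM in this assay, at which 2 of the 4 values shown sit. The new point is that a methyl ortho to a large group, like the 3-methylphenyl group of compound 3, shows no gain in this assay.

Going by these compounds, whether an amine or a carboxylic acid on the anilino group would give a step beyond the scatter remains open. So does whether a methoxy group ortho to a large group would yield a number rather than a limit.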